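The compounds below may be only part of what the source reports. "The series", "measured", "known", "first", "only" and "open" are said of these compounds alone.

Among the compounds with values here, the compounds measured so far in a functional assay on L1210 cells (Mus musculus) for cytotoxicity, with a stated time of 48 h (a lower number here means a stronger inhibitor, a higher number a weaker inhibitor), are these.
Compound 1, `Fc1ccc(-c2cn3nc(Cc4ccc(Cl)cc4)sc3n2)cc1`: compound 1 gives > 250000 nM, which is a limit of the assay and not a number.
Compound 2, `O=c1oc2ccccc2cc1-c1cn2nc(Cc3ccc(Cl)cc3)sc2n1`: compound 2 gives > 10000 nM, again a limit of the assay.
Compound 3, `Fc1ccc(-c2nc3sc(Cc4ccc(Cl)cc4)nn3c2Br)cc1`: compound 3 gives > 250000 nM, also a limit of the assay.

Compound 3 therefore stands nowhere in particular on the numbers shown: every value in this assay is a limit. Two of the three values sit at the limit of > 250000 nM in this assay, at which 2 of the 3 values shown sit, and one sits at the limit of > 10000 nM in this assay, at which 1 of the 3 values shown sits. Within the data shown here, the only step between measured compounds that differ in one place, a step that the two limits leave unreadable from compound 1 to compound 3, is unreadable because both ends are limits; its size is not known.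

Compound 4, `Clc1ccc(Cc2nn3c(Br)c(-c4ccc(Br)cc4)nc3s2)cc1`, differs from compound 3 by bromo in place of fluoro on an aromatic carbon. Among the measured compounds shown here, no measured step bears on an exchange of bromo for fluoro, and the one step that has been measured gives no size at all. Nothing in the shown data points to a change beyond the scatter in either direction. Compound 4 is therefore expected to give about 250000 nM in this assay, with a range from 50000 nM to 1000000 nM, most probably again reported only as a limit. This expectation corresponds to an estimated step of a number no higher from compound 3 to compound 4 (the limit leaves the size open).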

Compound 4, half-maximal inhibitory concentration: > 250000 nM
Compound 4 was reported as a limit; the forecaster's own chance of this, stated with the estimate: 85%; the middle value lies on the limit itself.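

In this assay compound 4 gives > 250000 nM, which is a limit of the assay and not a number. Compound 3 and compound 4 both stand at limits, so no size can be read for the step between them. The compounds shown leave open what bromo in place of fluoro does to the potency, and whether any of these compounds has a numerical value in this assay.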